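A few compounds are considered here, and "the series" means these few. Any claim that something is new, unique, unknown or untested is made for them only; others in the source may bear on it.

Measured so far in an ADME assay on WI-38 cells (Homo sapiens) for cytotoxicity, read by MTT assay, with a stated time of 72 h; a lower number here means a stronger inhibitor, a higher number a weaker inhibitor:
compound 1, `CN(C)CCn1cnnc1-c1cc(Oc2ccc(NC(=O)N/N=C/c3c(Cl)cccc3Cl)cc2F)ccn1`, 3320 nM
compound 2, `COc1ccc(/C=N/NC(=O)Nc2ccc(Oc3ccnc(-c4nncn4CCN(C)C)c3)c(F)c2)c(OC)c1OC`, "not determined" (no result reported)
compound 3, `CN(C)CCn1cnnc1-c1cc(Oc2ccc(NC(=O)N/N=C/c3ccc(F)cc3)cc2F)ccn1`, 3980 nM

Among the measured compounds shown here, compound 3 holds the higher of the two numbers available in this assay, but its only neighbour is compound 1, and the step of a 1.2-fold higher number from compound 1 to compound 3 (0.08 log units; within the scatter) lies within the scatter, so the two compounds cannot be ordered. Compound 2 contributes no number.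

Compound 4 is `CN(C)CCn1cnnc1-c1cc(Oc2ccc(NC(=O)N/N=C/c3ccc(F)cc3F)cc2F)ccn1`. It differs from compound 3 by fluoro in place of hydrogen on an aromatic carbon, so that the ring on the carbon with a double bond to nitrogen goes from 4-fluorophenyl to 2,4-difluorophenyl.

For the measured compounds named here, the one measured step that bears on this position is the exchange of the whole ring on that carbon, from compound 1 to compound 3, and it moved the number by a 1.2-fold higher number from compound 1 to compound 3 (0.08 log units; within the scatter), within the scatter. Going by the values given here, no measured step adds a single fluoro to this ring. With a ring exchange that large leaving the number essentially unchanged, a single added fluoro is expected to give no step beyond the scatter, in either direction.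

Compound 4 is therefore expected at 4000 nM in this assay, with a range of 2000 nM to 8000 nM, the expected step being a 1.0-fold higher number from compound 3 to compound 4 (0.00 log units; within the scatter).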

Compound 4, half-maximal inhibitory concentration: 5030 nM
For compound 4 the middle estimate is 1.3-fold (0.10 log units) below the measured one; the range from low to high includes it.
By their numbers in this assay, from the lowest: compounds 1, 3 and 4 (each within the scatter of the next).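

In this assay, among the compounds shown here, the single added fluoro on the ring at the carbon with a double bond to nitrogen, ortho to a large group, gives the first direct reading of this change (a step of a 1.3-fold higher number from compound 3 to compound 4 (0.10 log units; within the scatter)). A second ring exchange at the same carbon (a 1.5-fold higher number from compound 1 to compound 4 (0.18 log units; within the scatter)) also stays within the scatter, so 2,6-dichlorophenyl, 4-fluorophenyl and 2,4-difluorophenyl cannot be ordered here. No supporting data bear on this result.

Going by these compounds, all three rings with numbers carry only halogens, so it remains open whether an amine or a carboxylic acid on this ring would move the number beyond the scatter. Steps involving compound 2 cannot be read, leaving the trimethoxy-substituted ring without a comparison.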